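This account rests on a few compounds, and the source may have more. Where it says the series, first, only, none or still open, it means among the compounds named here.

Of the compounds shown here, three built on one shared core have been measured in an assay on isolated protein for binding affinity to Glucagon receptor (Homo sapiens); a higher number here means a weaker inhibitor, a lower number a stronger inhibitor. Compound 1 `CCc1c(C(C)C)nc(C(C)C)c(C(C)O)c1-c1ccc(F)cc1O` gives 20 nM. Compound 2 `CCCc1c(C(C)C)nc(C(C)C)c(C(C)O)c1-c1ccccc1O` gives 40 nM. Compound 3 `CCCc1c(C(C)C)nc(C(C)C)c(C(C)O)c1-c1ccc(F)cc1O` gives 18 nM, the lowest of the three numbers; compound 1 sits nearest to it, and a 1.1-fold lower number from compound 1 to compound 3 (0.05 log units; within the scatter) lies within the scatter, so no order between these two can be read. Compound 2 is furthest, and a 2.2-fold lower number from compound 2 to compound 3 (0.35 log units; beyond the scatter) is a modest step beyond the scatter.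

Compound 4 `CCCCCc1c(C(C)C)nc(C(C)C)c(C(C)O)c1-c1ccc(F)cc1O` has not yet been measured. It differs from compound 3 by ethyl in place of hydrogen on a saturated chain carbon, three bonds along the chain from an aromatic carbon. Going by the values given here, the one measured step that speaks to this kind of change is the step from compound 1 to compound 3, which extended the same chain and gave a 1.1-fold lower number from compound 1 to compound 3 (0.05 log units; within the scatter), no change beyond the scatter. The fluoro step from compound 2 to compound 3 concerns a different part of the molecule and does not bear on a chain extension. Among the compounds with values here, with only one comparable step, and that one flat, the expected move in this assay for compound 4 is a 1.1-fold higher number from compound 3 to compound 4 (0.05 log units; within the scatter), that is, nothing beyond the scatter, with a wider range to allow for the longer extension. Compound 4 is therefore estimated at 20 nM, in the range 8 nM to 50 nM.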

Compound 4, half-maximal inhibitory concentration: 30 nM
Compound 4: the middle estimate sits 1.5-fold (0.18 log units) below what was measured; the range from low to high includes it.
By their numbers in this assay, from the lowest: compounds 3, 1, 4 and 2 (each within the scatter of the next, the first and the last beyond it).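

Going from a propyl to a pentyl chain at this position gives a 1.7-fold higher number from compound 3 to compound 4 (0.22 log units; within the scatter), and the longer change from an ethyl to a pentyl chain gives a 1.5-fold higher number from compound 1 to compound 4 (0.18 log units; within the scatter). The earlier compounds shown here tested only a single added carbon on this chain, whereas these steps show that even a pentyl chain brings no change that can be read in this assay. Ethyl, propyl and pentyl chains therefore cannot be told apart at this position, and no separate measurement bears on why they read alike.

The compounds shown leave open whether this flat reading extends to a shorter methyl group or to a chain longer than pentyl, such as heptyl. They also leave open what happens when the chain is branched, carries a phenyl ring, or ends in an amine or a carboxylic acid, as the three chains compared here are all unbranched and made of carbon alone.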